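Two measured compounds and one untested naphthalen-1-yl analogue

This account rests on a few compounds, and the source may have more. Where it says the series, first, only, none or still open, it means among the compounds named here.

Compound 1 `COc1ccc(SCc2ccc(/C=C/C(=O)Nc3ccccc3N)cc2)cc1OC`: 12.9%
Compound 2 `Nc1ccccc1NC(=O)c1ccc(CSc2ccc(Br)cc2)cc1`: 9.96%

In a functional assay on HCT-116 cells (Homo sapiens) for inhibition, read by CCK-8 assay, with a stated time of 72 h, tested at 2 uM (a lower number here means less inhibition of growth, a higher number more inhibition of growth at the concentration tested), compound 1 gives 12.9%; compound 2 is separated from it by less than the usual scatter, so the two read alike and neither can be ranked above the other. Compound 3 `Nc1ccccc1NC(=O)/C=C/c1ccc(CSc2cccc3ccccc23)cc1` has not yet been measured in this assay. It differs from compound 1 in one place: naphthalen-1-yl in place of 3,4-dimethoxyphenyl on a sulfur. Within the data shown here, no measured pair shows the effect of such a swap, so the step of a number 1.1 percentage points higher from compound 1 to compound 3 (within the scatter) is expected to stay within the scatter, with no clear direction. For compound 3 the estimated value is 14%, ranging from 3% to 28%.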

Compound 3, percent growth inhibition at one concentration: 11%
Compound 3: the middle estimate sits 3 percentage points above what was measured, and the stated range covers the measured number.
By their numbers in this assay, from the lowest: compounds 2, 3 and 1 (each within the scatter of the next).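

In this assay, among these compounds, the step of a number 1.9 percentage points lower from compound 1 to compound 3 (within the scatter) is the first measured swap on this sulfur. Naphthalen-1-yl brings a second aromatic ring and no oxygen atoms in place of 3,4-dimethoxyphenyl, yet the two compounds read alike at this single concentration. Nothing measured here offers an explanation for this result. 

From the compounds shown here alone, it remains open whether a group of a different kind on the sulfur, such as a carboxylic acid or an amine, would separate from these two. A longer chain between the sulfur and the aromatic ring is equally untested by the compounds shown.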